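Swapping a chlorophenyl for a pyridyl on a shared core

This account rests on a few compounds, and the source may have more. Where it says the series, first, only, none or still open, it means among the compounds named here.

Compound 1 `Cc1nc(-c2cccnc2)sc1-c1nnc(-c2ccc(Cl)cc2)o1` was tested in an ADME assay on HCT-116 cells (Homo sapiens) for cytotoxicity, read by MTT assay; on this read-out higher numbers stand for lower toxicity in this test and lower numbers for higher toxicity in this test. In this assay compound 1 gives > 100 ug/mL, which is a limit of the assay rather than a number. Compound 2 `Cc1nc(-c2cccnc2)sc1-c1nnc(-c2ccccc2[N+](=O)[O-])o1` likewise reaches only a limit in this assay, giving > 100 ug/mL. Among the measured compounds shown here, on the numbers so far compound 1 stands only at the limit of > 100 ug/mL in this assay, at which 2 of the 2 values shown sit. Compound 3 `Cc1nc(-c2cccnc2)sc1-c1nnc(-c2ccncc2)o1` differs from compound 1 by pyridin-4-yl in place of 4-chlorophenyl on an aromatic carbon. For the measured compounds named here, no step between measured compounds is known, so in this assay the change from compound 1 to compound 3 is expected to be a step that the limit leaves unreadable from compound 1 to compound 3, none beyond the scatter. Compound 3 is expected to give about 150 ug/mL, within 60 ug/mL to 400 ug/mL.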

Compound 3, half-maximal cytotoxic concentration: > 100 ug/mL
Compound 3: a limit, no number; the forecaster's own chance of this, stated with the estimate: 85%; the middle value does not contradict the limit.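

Among the compounds shown here, compound 1 and compound 3 each give a limit rather than a number, so no step between them can be read in this assay. The compounds shown leave open whether changing this group on the shared core alters the read-out at all, as all of them sit at the same limit: the limit of > 100 ug/mL in this assay, at which 3 of the 3 values shown sit.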